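Extending a Methyl to Ethyl on the Aryl Ring

This account rests on a few compounds, and the source may have more. Where it says the series, first, only, none or still open, it means among the compounds named here.

Of the compounds shown here, three built on one shared core have been tested in a functional assay on HL-60 cells (Homo sapiens) for cytotoxicity, read by WST assay, with a stated time of 48 h; a lower number here means that less compound is needed, a higher number that more compound is needed for the effect. Compound 1 `COc1ccccc1C[C@H]1COC[C@@H]1Cc1ccc(Cl)c(Cl)c1` gives 55000 nM in this assay. Compound 2 `CCOc1ccccc1C[C@H]1COC[C@@H]1Cc1ccc(Cl)c(Cl)c1` differs from compound 1 by methyl in place of hydrogen on a saturated chain carbon bound to an oxygen on an aromatic ring, and in this assay compound 2 gives 29000 nM; that step was a 1.9-fold lower number from compound 1 to compound 2 (0.28 log units; within the scatter). Compound 3 `Cc1ccc(C[C@H]2COC[C@@H]2Cc2ccc(Cl)c(Cl)c2)cc1` gives 21000 nM in this assay; how the core of compound 3 differs from that of compound 1 is not broken down here.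

Compound 4 `CCc1ccc(C[C@H]2COC[C@@H]2Cc2ccc(Cl)c(Cl)c2)cc1` has not yet been measured. It differs from compound 3 by methyl in place of hydrogen on a saturated chain carbon bound to an aromatic carbon. This is the same kind of change as that from compound 1 to compound 2, but not the same: there the methyl entered on a saturated chain carbon bound to an oxygen on an aromatic ring, here on a saturated chain carbon bound to an aromatic carbon. Among the measured compounds shown here, the only guide is a 1.9-fold lower number from compound 1 to compound 2 (0.28 log units; within the scatter), a single pair at a different place. For compound 4 a step of similar size is expected, a 1.4-fold lower number from compound 3 to compound 4 (0.15 log units; within the scatter). Compound 4 is therefore estimated to give 15000 nM in this assay, expected to fall between 6000 nM and 40000 nM.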

Compound 4, half-maximal effective concentration: 26000 nM
The estimate for compound 4 lay 1.7-fold (0.24 log units) below the measured number; the range from low to high includes it.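

In this assay, lengthening methyl to ethyl on the core of compound 3 gave a 1.2-fold higher number from compound 3 to compound 4 (0.09 log units; within the scatter), a step too small to tell apart from no change at all. Set beside the earlier step on the other core, the two steps do not differ by more than measurement scatter allows: the same change on two cores in this assay, a 1.9-fold lower number (0.28 log units; within the scatter) from compound 1 to compound 2 and a 1.2-fold higher number (0.09 log units; within the scatter) from compound 3 to compound 4, 2.3-fold (0.37 log units) apart, within the scatter of two such steps

As far as these results go, the change behaved alike on both cores, but this does not establish a rule that carries over, since each core offers a single pair, the change sits at a different place in each, and neither step stands clear of the scatter.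

The compounds shown leave open whether a longer chain such as propyl, or a group of another kind such as an amine or a carboxylic acid, at this place would move the number beyond the scatter. Going by these compounds, all four compounds also keep the same chlorine atoms, so what a change there would do remains open too.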